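Swapping Cyclohexyl for Trifluoromethyl on a Receptor Agonist

The compounds below may be only part of what the source reports. "The series", "measured", "known", "first", "only" and "open" are said of these compounds alone.

Compound 1 `CC#CC(CC(=O)O)c1ccc(OCc2ccn3cc(-c4ccc(C)cc4)nc3c2)cc1`: 618 nM
Compound 2 `CC#CC(CC(=O)O)c1ccc(OCc2ccn3cc(-c4ccccc4C)nc3c2)cc1`: 459 nM
Compound 3 `CC#CC(CC(=O)O)c1ccc(OCc2ccn3cc(-c4ccc(C5CCCCC5)cc4)nc3c2)cc1`: 559 nM

In an assay on isolated protein for agonist activity at Free fatty acid receptor 1 (Homo sapiens) (on this read-out lower numbers stand for an effect already at smaller amounts and higher numbers for an effect only at larger amounts of compound), compound 3 gives 559 nM, the second highest of the three numbers. Its neighbours sit close: a 1.1-fold lower number from compound 1 to compound 3 (0.04 log units; within the scatter) and a 1.2-fold higher number from compound 2 to compound 3 (0.09 log units; within the scatter) are both within the scatter. Compound 4 `CC#CC(CC(=O)O)c1ccc(OCc2ccn3cc(-c4ccc(C(F)(F)F)cc4)nc3c2)cc1` differs from compound 3 in one place: trifluoromethyl in place of cyclohexyl on an aromatic carbon. The step that bears most directly on this change is the swap at the same place, a 1.1-fold lower number from compound 1 to compound 3 (0.04 log units; within the scatter), which stayed within the scatter; so did a 1.3-fold lower number from compound 1 to compound 2 (0.13 log units; within the scatter). Within the data shown here, no measured compound carries a trifluoromethyl group, so there is no direct guide. On this basis no step beyond the scatter is expected, a 1.0-fold higher number from compound 3 to compound 4 (0.00 log units; within the scatter). Compound 4 is therefore estimated at 560 nM, within a range from 250 nM to 1250 nM.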

Compound 4, half-maximal effective concentration: 674 nM
Beside the measured number, compound 4's estimate is 1.2-fold (0.08 log units) below it; the range from low to high includes it.
By their numbers in this assay, from the lowest: compounds 2, 3, 1 and 4 (each within the scatter of the next).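

The swap gives a 1.2-fold higher number from compound 3 to compound 4 (0.08 log units; within the scatter) in this assay and so shows that a group with no ring can replace the six-membered ring of cyclohexyl at this place without a readable change. The same holds for a 1.1-fold higher number from compound 1 to compound 4 (0.04 log units; within the scatter) and for a 1.5-fold higher number from compound 2 to compound 4 (0.17 log units; within the scatter) so compound 4 stays within the scatter of all three earlier compounds. On this aromatic carbon, methyl, cyclohexyl and trifluoromethyl cannot be told apart.

Open, from the compounds shown here alone, is whether any group here, such as an amine or a carboxylic acid, would move the number beyond the scatter. No measurement shown explains why these groups read alike.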